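Acetylated glycosyl triazole series: cytotoxicity notes

This account rests on a few compounds, and the source may have more. Where it says the series, first, only, none or still open, it means among the compounds named here.

Measured so far:
- compound 1 `CC(=O)OC[C@H]1O[C@@H](n2cc(Cn3cc(/C=C4/C(=O)Nc5ccccc54)c4ccccc43)nn2)[C@H](OC(C)=O)[C@@H](OC(C)=O)[C@@H]1OC(C)=O` — > 200000 nM in this assay (a limit)
- compound 2 `CC(=O)OC[C@H]1O[C@@H](n2cc(CN3C(=O)/C(=C/c4ccc(C)cc4)c4ccccc43)nn2)[C@H](OC(C)=O)[C@@H](OC(C)=O)[C@@H]1OC(C)=O` — 85600 nM
- compound 3 `CC(=O)OC[C@H]1O[C@@H](n2cc(CN3C(=O)/C(=C\c4ccc(C)cc4)c4ccccc43)nn2)[C@H](OC(C)=O)[C@@H](OC(C)=O)[C@@H]1OC(C)=O` — > 100000 nM (a limit)

In a functional assay on HeLa cells (Homo sapiens) for cytotoxicity, read by sulforhodamine B assay, with a stated time of 48 h (on this read-out lower numbers stand for stronger inhibition and higher numbers for weaker inhibition), compound 1 reaches only the limit (the limit of > 200000 nM in this assay, at which 1 of the 3 values shown sits). Among the compounds with values here, compound 2 is the one member with a numeric value, 85600 nM. Compound 3 gives a limit, > 100000 nM. Among the three, compound 3 therefore stands with the limits, and the one step measured in it, an at least 1.1-fold higher number from compound 2 to compound 3 (0.06 log units; that floor lies within the scatter), rests on the fact that compounds 2 and 3 differ only in the configuration as drawn and lies within the scatter, so nothing in the recorded numbers separates compound 3 from compound 2.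

Compound 4 `CC(=O)OC[C@H]1O[C@@H](n2cc(CN3C(=O)/C(=C\c4ccco4)c4ccccc43)nn2)[C@H](OC(C)=O)[C@@H](OC(C)=O)[C@@H]1OC(C)=O` differs from compound 3 by furan-2-yl in place of 4-methylphenyl on a double-bonded chain carbon bound to a double-bonded ring carbon, with the double bond kept as drawn in compound 3. Within the data shown here, no measured step touches this kind of exchange; the only step on record, an at least 1.1-fold higher number from compound 2 to compound 3 (0.06 log units; that floor lies within the scatter), concerns configuration alone and is within the scatter, and the wider context is the limit of > 100000 nM in this assay, at which 1 of the 3 values shown sits, and (the limit of > 200000 nM in this assay, at which 1 of the 3 values shown sits), both limits. The expectation is thus a step of a number no higher from compound 3 to compound 4 (the limit leaves the size open) in this assay, no direction beyond the scatter, with a fair chance of another limit. Compound 4 is estimated at 100000 nM, within 40000 nM to 300000 nM.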

Compound 4, half-maximal inhibitory concentration: > 100000 nM
Compound 4 was reported as a limit (the forecaster's own chance of this, stated with the estimate: 60%); the middle value lies on the limit itself.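

Compound 3 and compound 4 both give only a limit in this assay, so the exchange of 4-methylphenyl for furan-2-yl yields no readable step between them. The compounds shown leave open whether this exchange changes cytotoxicity at all, and how far either compound lies beyond its limit.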